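The source may hold more compounds than are shown below. What is called first, only, known or untested is meant among the compounds shown, and "the series" means these compounds.

Measured compounds:

Compound 1, `Cc1ccccc1Cn1cc(C(=N)S)c2c(N)ncnc21`. In a functional assay on KB cells (Homo sapiens) for cytotoxicity (on this read-out higher numbers stand for weaker inhibition and lower numbers for stronger inhibition), compound 1 gives > 17000 nM, which is a limit of the assay and not a number.

Compound 2, `N#Cc1cn(COCc2ccccc2)c2ncnc(N)c12`. In this assay compound 2 gives > 100000 nM, again a limit.

Compound 3, `Cc1ccccc1Cn1cc(C#N)c2c(N)ncnc21`. In this assay compound 3 gives > 100000 nM, also a limit.

Compound 1 therefore stands only at a limit, namely (the limit of > 17000 nM in this assay, at which 1 of the 3 values shown sits). The other two values sit at the limit of > 100000 nM in this assay, at which 2 of the 3 values shown sit. Going by the values given here, the one step between measured compounds that differ in one place is a step that the two limits leave unreadable from compound 1 to compound 3; with both ends at limits, its size cannot be read.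

The unmeasured compound 4, `CCCn1cc(C(=N)S)c2c(N)ncnc21`, differs from compound 1 as follows: ethyl in place of 2-methylphenyl on a saturated chain carbon bound to an aromatic nitrogen.

Among the compounds with values here, no measured step touches this change at the saturated chain carbon bound to the aromatic nitrogen; the only step known, a step that the two limits leave unreadable from compound 1 to compound 3, concerns a different place and is unreadable anyway. There is thus no basis for expecting a step of any particular size or direction in this assay, and the most likely outcome is that compound 4, like all three measured compounds, also comes back at a limit. The expected step from compound 1 is a step that the limit leaves unreadable from compound 1 to compound 4. Compound 4 is estimated at 40000 nM, with a range from 5000 nM to 300000 nM.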

Compound 4, half-maximal inhibitory concentration: 17000 nM
The estimate for compound 4 lay 2.4-fold (0.37 log units) above the measured number, within the range that was stated.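

In this assay compound 4 gives 17000 nM, the only true number among the compounds shown, so a value can be read with ethyl in place of 2-methylphenyl on the saturated chain carbon bound to the aromatic nitrogen. Compound 1 gives > 17000 nM, which is a limit and not a number. The step is a number no higher from compound 1 to compound 4 (the limit leaves the size open) and its size cannot be read, and the change shows only that losing the aromatic ring at this place does not raise the number, because one end of the step sits at a limit: the limit of > 17000 nM in this assay, at which 1 of the 4 values shown sits.

The compounds shown leave open how far the number moves at this place with a longer chain such as butyl, or with a chain ending in an amine or a carboxylic acid, and whether any such group would bring it lower than compound 4. They also leave open what ethyl would do in a compound carrying the nitrile of compound 3, since that nitrile appears here only with larger groups at this place.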